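A short chain grows on a shared quinone core

The source may report more compounds than this note shows. Statements on the series, on what has been measured and on what is new or still open speak of the compounds shown alone.

This piece follows one small change on a common core and asks what it should do to cytotoxicity. Three compounds have been looked at so far. Compound 1, with the structure `CCCCCCCC1=CC(=O)C=C(OC)C1=O`, has a result: in a functional assay on A2780 cells (Homo sapiens) for cytotoxicity (on this read-out higher numbers stand for weaker inhibition and lower numbers for stronger inhibition), compound 1 gives 7.9 ug/mL. Compound 2, with the structure `COC1=CC(=O)C=C(C)C1=O`, has no result; in this assay the entry for compound 2 reads "not determined" (no result reported). Compound 3, with the structure `CCC1=CC(=O)C=C(OC)C1=O`, is in the same position, and for compound 3 the entry reads "not determined" (no result reported). So compound 2 stands nowhere on the numbers: it has none, and it shares that with one further compound, compound 3.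

Compound 4, with the structure `CCCCC1=CC(=O)C=C(OC)C1=O`, has not been tested. It differs from compound 2 in one place: propyl in place of hydrogen on a saturated chain carbon bound to a double-bonded ring carbon. Among the measured compounds shown here, because no two measured compounds differ in a single place, no step of this kind has been seen here, and the only anchor is compound 1 with its value of 7.9 ug/mL, which also carries a chain on the same core. On that footing the expectation is a modest result in the same region, with no firm direction beyond the scatter.

For compound 4 the estimate in this assay is 12 ug/mL, expected to fall between 4 ug/mL and 40 ug/mL.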

Compound 4, half-maximal inhibitory concentration: 3.2 ug/mL
For compound 4 the middle estimate is 3.8-fold (0.57 log units) above the measured one, and the stated range ends above it.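

In this assay this position now has its first readable step: a 2.5-fold lower number from compound 1 to compound 4 (0.39 log units; beyond the scatter), a modest change but one beyond the scatter, and here a lower number means stronger inhibition. On the shared core, then, the length of the chain does alter the result, and the butyl chain of compound 4 gives stronger inhibition than the longer chain of compound 1, although the change from compound 2 to compound 4, methyl to butyl, cannot be read, as compound 2 has no number. Nothing available explains the difference between these two chains.

From the compounds shown here alone, this single pair sets no trend, so it remains open whether inhibition would keep strengthening, level off or fall away as the chain shortens to the methyl of compound 2 or the ethyl of compound 3. Also open, going by these compounds, is how compound 4 would compare with a chain of similar length ending in an amine or a carboxylic acid, which would show whether anything other than a plain carbon chain can be carried at this position.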